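Replacing the saturated ring with 2-fluorophenyl

A few compounds are considered here, and "the series" means these few. Any claim that something is new, unique, unknown or untested is made for them only; others in the source may bear on it.

Among the measured compounds shown here, in a functional assay on MCF-10A cells (Homo sapiens) for antiproliferative activity, with a stated time of 48 h (a higher number here means that more compound is needed for the effect, a lower number that less compound is needed), compound 1 `COc1ccc2nc(C)cc(NCc3ccc(C)cc3)c2c1` stands at 22400 nM and compound 2 `COc1ccc2nc(C)cc(NCC3CCCN(C)C3)c2c1` at 5800 nM as the lower of the two numbers so far. Compound 3 `COc1ccc2nc(C)cc(NCc3ccccc3F)c2c1` has 2-fluorophenyl in place of 1-methylpiperidin-3-yl on a saturated chain carbon bound to a nitrogen on an aromatic ring. For the measured compounds named here, the one measured step bearing on this change is a 3.9-fold lower number from compound 1 to compound 2 (0.59 log units; beyond the scatter) with 1-methylpiperidin-3-yl in place of 4-methylphenyl at the same place. Going by the values given here, compound 3 brings back an aromatic ring, so a step of similar size towards a higher number is expected, although no fluorinated compound has been measured. The expected change is a 2.8-fold higher number from compound 2 to compound 3 (0.44 log units; beyond the scatter) in this assay on this reasoning. Compound 3 is estimated at 16000 nM with a range from 7000 nM to 35000 nM in this read-out.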

Compound 3, half-maximal effective concentration: 17000 nM
Beside the measured number, compound 3's estimate is 1.1-fold (0.03 log units) below it, and the stated range covers the measured number.
By their numbers in this assay, from the lowest: compound 2; then compounds 3 and 1 (each within the scatter of the next).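

In this assay, bringing an aromatic ring back on the saturated chain carbon bound to a nitrogen on an aromatic ring gives a 2.9-fold higher number from compound 2 to compound 3 (0.47 log units; beyond the scatter), so the lower number of compound 2 now stands against two aromatic groups rather than one. The two aromatic groups are not separated, with a 1.3-fold lower number from compound 1 to compound 3 (0.12 log units; within the scatter), while compound 2 keeps the lowest number of the three, its steps to both lying beyond the scatter. Nothing measured here accounts for these steps.

Which part of 1-methylpiperidin-3-yl goes with the lower number stays open: a cyclohexyl group or an open-chain dimethylamino group at this place would separate the saturated ring from the amine. Also open, on these data alone, is how a longer chain carrying 1-methylpiperidin-3-yl would read in this assay.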